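Swapping pyridinyl for furanyl on the shared core

The compounds below may be only part of what the source reports. "The series", "measured", "known", "first", "only" and "open" are said of these compounds alone.

Measured so far in an ADME assay on HEK293 cells (Homo sapiens) for cytotoxicity, read by CCK-8 assay and cell counting, with a stated time of 2 days; a lower number here means a stronger inhibitor, a higher number a weaker inhibitor:
- Compound 1 `Oc1ccc(-c2cc(-c3ccc(Cl)cc3)nc(-c3cccs3)c2)cc1`: 4520 nM
- Compound 2 `Oc1ccc(-c2cc(-c3ccc(Cl)cc3)nc(-c3ccccn3)c2)cc1`: 27200 nM

Compound 2 has the highest number of the two; its nearest neighbour is compound 1, and the step of a 6.0-fold higher number from compound 1 to compound 2 (0.78 log units; beyond the scatter) lies beyond the scatter. Compound 3 `Oc1ccc(-c2cc(-c3ccc(Cl)cc3)nc(-c3ccco3)c2)cc1` differs from compound 2 in one place: furan-2-yl in place of pyridin-2-yl on an aromatic carbon. Within the data shown here, the only measured step that bears on this is a 6.0-fold higher number from compound 1 to compound 2 (0.78 log units; beyond the scatter), a modest rise when a thiophen-2-yl gave way to a pyridin-2-yl. Furan-2-yl resembles the thiophen-2-yl of compound 1 more than it resembles pyridin-2-yl, so the change from compound 2 to compound 3 is expected to roughly undo that step, with the number falling toward that of compound 1 rather than staying where compound 2 sits. For compound 3 the expected step in this assay is a 3.9-fold lower number from compound 2 to compound 3 (0.59 log units; beyond the scatter). Compound 3 is therefore estimated at 7000 nM, within a range of 2500 nM to 20000 nM.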

Compound 3, half-maximal inhibitory concentration: 5720 nM
Beside the measured number, compound 3's estimate is 1.2-fold (0.09 log units) above it, within the range that was stated.
By their numbers in this assay, from the lowest: compounds 1 and 3 (each within the scatter of the next); then compound 2.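

In this assay, furan-2-yl in place of pyridin-2-yl brings a clear change (a 4.8-fold lower number from compound 2 to compound 3 (0.68 log units; beyond the scatter)), whereas furan-2-yl in place of thiophen-2-yl does not (a 1.3-fold higher number from compound 1 to compound 3 (0.10 log units; within the scatter)). Among these compounds, at this position, then, the two five-membered aromatic rings cannot be told apart, and the higher number of compound 2 sets its six-membered pyridin-2-yl apart from both of them, which the single step from thiophen-2-yl could not show. Nothing measured here explains this difference.

Still open, going by these compounds, is whether the separation follows ring size or the ring nitrogen, a question that an unsubstituted phenyl group at the same place would help to settle. Also open, on these data alone, is how a non-aromatic group at this position, such as a morpholine ring or a short alkyl chain, would compare.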